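This account rests on a few compounds, and the source may have more. Where it says the series, first, only, none or still open, it means among the compounds named here.

In a functional assay on A549 cells (Homo sapiens) for inhibition, read by MTT assay, with a stated time of 24 h (a lower number here means a stronger inhibitor, a higher number a weaker inhibitor), compound 1 `CC1(C)[C@H]2CC[C@]1(C)N(Cc1cn(-c3cccc(F)c3)nn1)C(=O)C2` gives 180 nM and compound 2 `CC1(C)[C@H]2CC[C@]1(C)N(Cc1cn(-c3ccc(F)cc3)nn1)C(=O)C2` gives 230 nM, while compound 3 `Cc1ccccc1-n1cc(CN2C(=O)C[C@@H]3CC[C@@]2(C)C3(C)C)nn1` gives 90 nM on the same core. Among the measured compounds shown here, compound 3 stands with compound 1, the step between them being a 2.0-fold lower number from compound 1 to compound 3 (0.30 log units; within the scatter) in this pair, and it sits modestly clear of compound 2, with a 2.6-fold lower number from compound 2 to compound 3 (0.41 log units; beyond the scatter) as the one step here beyond the scatter.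

Compound 4 `COc1ccc(-n2cc(CN3C(=O)C[C@@H]4CC[C@@]3(C)C4(C)C)nn2)cc1` is still unmeasured and carries 4-methoxyphenyl in place of 2-methylphenyl on an aromatic nitrogen in the five-membered aromatic ring. No methoxyphenyl has been measured, so the nearest guide is compound 2, the other compound with a group at the 4 position of the phenyl. Moving fluorine between the two fluorophenyl compounds gave only a 1.3-fold higher number from compound 1 to compound 2 (0.11 log units; within the scatter) as a shift. A modest step toward a higher number is therefore expected in this assay, of about the size seen between compound 2 and compound 3. The estimated step is a 2.2-fold higher number from compound 3 to compound 4 (0.35 log units; beyond the scatter) at the middle of the range. For compound 4 the expected value is 200 nM with an estimated range of 80 nM to 450 nM as it stands.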

Compound 4, half-maximal inhibitory concentration: 50 nM
The estimate for compound 4 lay 4.0-fold (0.60 log units) above the measured number, outside the stated range (below it).
By their numbers in this assay, from the lowest: compounds 4, 3, 1 and 2 (each within the scatter of the next, the first and the last beyond it).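

In this assay, among the compounds shown here, the group on the aromatic carbon of the 4-substituted phenyl matters: methoxy in place of fluoro gives a 4.6-fold lower number from compound 2 to compound 4 (0.66 log units; beyond the scatter), the largest step so far. The 4-methoxyphenyl group also stands clear of 3-fluorophenyl, with a 3.6-fold lower number from compound 1 to compound 4 (0.56 log units; beyond the scatter), but a 1.8-fold lower number from compound 3 to compound 4 (0.26 log units; within the scatter) does not separate it from 2-methylphenyl, so compound 4 and compound 3 share the low end of the series. No measurement here accounts for the difference between methoxy and fluoro on this ring.

Still open, going by these compounds, is whether 4-ethoxyphenyl, with a longer chain, or 4-aminophenyl, with an amine, would keep the number of compound 4 or shift it. On these data alone, the effect of a methoxy group elsewhere on the phenyl ring also remains unknown.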